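The compounds below may be only part of what the source reports. "The series", "measured", "known", "first", "only" and "open" are said of these compounds alone.

Working notes on a urea-linked hydrazone series sharing one core. Compound 1 `CN(C)CCn1cnnc1-c1cc(Oc2ccc(NC(=O)N/N=C/c3cc(Br)c(O)c(Br)c3)cc2F)ccn1` carries a 3,5-dibromo-4-hydroxyphenyl hydrazone; for compound 1 the entry in an ADME assay on WI-38 cells (Homo sapiens) for cytotoxicity, read by MTT assay, with a stated time of 72 h (on this read-out lower numbers stand for stronger inhibition and higher numbers for weaker inhibition), reads "not determined" (no result reported), so no number is available. Going by the values given here, compound 2 `CN(C)CCn1cnnc1-c1cc(Oc2ccc(NC(=O)N/N=C/c3ccccc3O[N+](=O)[O-])cc2F)ccn1` is the only member with a figure: in this assay compound 2 gives 6860 nM, which therefore stands alone as the sole reference point, with one further entry lacking a number.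

The next compound, compound 3 `CN(C)CCn1cnnc1-c1cc(Oc2ccc(NC(=O)N/N=C/c3ccc(Cl)cc3Cl)cc2F)ccn1`, differs from compound 2 in one place: 2,4-dichlorophenyl in place of 2-(nitrooxy)phenyl on a carbon with a double bond to nitrogen. Among the compounds with values here, no measured step exists for such a swap within this set, so the expected size of the step rests on the single figure for compound 2 alone. A modest shift toward stronger inhibition, close to the edge of the usual scatter, is expected: a 1.4-fold lower number from compound 2 to compound 3 (0.14 log units; within the scatter). On that basis compound 3 is estimated at 5000 nM in this assay, within a range of 1500 nM to 16000 nM.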

Compound 3, half-maximal inhibitory concentration: 4760 nM
Beside the measured number, compound 3's estimate is 1.1-fold (0.02 log units) above it; the measured number falls inside the stated range.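

In this assay, going by these compounds alone, the first measured swap on a carbon with a double bond to nitrogen, 2,4-dichlorophenyl in place of 2-(nitrooxy)phenyl, gives a 1.4-fold lower number from compound 2 to compound 3 (0.16 log units; within the scatter), so the two compounds cannot be told apart on this read-out. Compound 2 and compound 3 thus give matching cytotoxicity readings although the entering group carries chlorine and no hydrogen-bond acceptors, while the leaving group carries nitrogen, oxygen and hydrogen-bond acceptors. No measured evidence here bears on the reason for this result.

Open, going by these compounds, is whether an amine or a carboxylic acid in place of the aromatic ring on this carbon would give a number beyond the scatter from compound 2. Equally open, on these data alone, is how plain phenyl, without any substituent, would read in this assay.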